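The compounds below may be only part of what the source reports. "The series", "measured", "known", "first", "only" and "open" are said of these compounds alone.

Compound 1, `NC(=O)c1c(NC(=O)c2ccc(C(F)(F)F)cc2)sc2c1CCN(Cc1c(Cl)cccc1Cl)C2`, gives 10600 nM in a functional assay on HL-60 cells (Homo sapiens) for antiproliferative activity, with a stated time of 24 h; a higher number here means a weaker inhibitor, a lower number a stronger inhibitor.
Compound 2, `Cc1ccc(C(=O)Nc2sc3c(c2C(N)=O)CCN(Cc2c(Cl)cccc2Cl)C3)cc1`, gives 10000 nM in this assay.
Compound 3, `NC(=O)c1c(NC(=O)c2ccccc2C(F)(F)F)sc2c1CCN(C(=S)Nc1ccccc1Cl)C2`, gives 17600 nM in this assay.

The three measured numbers sit within the usual scatter of one another, so no order among compounds 1, 2 and 3 can be read from them. Compound 4, `Cc1ccccc1C(=O)Nc1sc2c(c1C(N)=O)CCN(C(=S)Nc1ccccc1Cl)C2`, has not yet been measured in this assay. It is made from compound 3 by one change: methyl in place of trifluoromethyl on an aromatic carbon. The same kind of change has been measured once already, from compound 1 to compound 2: methyl in place of trifluoromethyl on an aromatic carbon. That measured pair gave a 1.1-fold lower number from compound 1 to compound 2 (0.03 log units; within the scatter), a step that lies inside the scatter. The two places are not identical: in the measured pair the group sits para to a large group, while in the pair from compound 3 to compound 4 it sits ortho to a large group, so the two changes are of the same kind rather than the same. Compound 3 and compound 1 also differ in their cores, and the difference between the two cores is not broken down here. Resting on the flat step from compound 1 to compound 2, compound 4 is expected to show a 1.1-fold lower number from compound 3 to compound 4 (0.04 log units; within the scatter), a step of about the same small size in this assay. For compound 4 the estimated value in this assay is 16000 nM, expected to fall between 7000 nM and 40000 nM.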

Compound 4, half-maximal inhibitory concentration: 20900 nM
For compound 4 the middle estimate is 1.3-fold (0.12 log units) below the measured one; measured number inside the range.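

In this assay, the exchange of 2-(trifluoromethyl)phenyl for 2-methylphenyl gives a 1.2-fold higher number from compound 3 to compound 4 (0.07 log units; within the scatter), so no effect of this change can be read on the core of compound 3. Set beside the earlier pair, the change reads alike on both cores: the same change on two cores in this assay, a 1.1-fold lower number (0.03 log units; within the scatter) from compound 1 to compound 2 and a 1.2-fold higher number (0.07 log units; within the scatter) from compound 3 to compound 4, 1.3-fold (0.10 log units) apart, within the scatter of two such steps. This shows only that methyl and trifluoromethyl could not be told apart in these two pairs; it does not show that the change would stay flat on any other core, and with the group in a different place in each pair, the two pairs cannot separate the effect of its place from that of the core, while two flat steps say nothing about how a step of readable size would carry over.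

The compounds shown leave open how an amine, a carboxylic acid, a methoxy group or a longer alkyl chain would read on the same aromatic carbon in this assay. Within the data shown here, the contribution of the cores themselves also stays unread: compounds on one core differ from those on the other in more than one place, and no single step connects them.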